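Aryl Swap on the Urea Nitrogen of Compound 2

The compounds below may be only part of what the source reports. "The series", "measured", "known", "first", "only" and "open" are said of these compounds alone.

Two ureas sharing the same core have been measured in a functional assay on HT-29 cells (Homo sapiens) for cytotoxicity, read by MTT assay, with a stated time of 72 h; on this read-out higher numbers stand for weaker inhibition and lower numbers for stronger inhibition. Compound 1 `CN(C)CCNc1nc(-c2ccc(NC(=O)Nc3ccc(F)cc3)cc2)nc2ccsc12` gives 350 nM, and compound 2 `CN(C)CCNc1nc(-c2ccc(NC(=O)Nc3ccccc3Cl)cc2)nc2ccsc12` gives 310 nM. The two numbers lie within the scatter of each other, as the step of a 1.1-fold lower number from compound 1 to compound 2 (0.05 log units; within the scatter) shows, so compound 2 stands beside compound 1 rather than apart from it. Compound 3 `Cc1ccc(NC(=O)Nc2ccc(-c3nc(NCCN(C)C)c4sccc4n3)cc2)cc1` is not yet measured. It differs from compound 2 by 4-methylphenyl in place of 2-chlorophenyl on an amide-type nitrogen. For the measured compounds named here, the only measured step that bears on this change, another swap of one aryl group for another on the same nitrogen, reads a 1.1-fold lower number from compound 1 to compound 2 (0.05 log units; within the scatter). On that basis no step beyond the scatter is expected in this assay for this change. The expected step from compound 2 to compound 3 is a 1.1-fold higher number from compound 2 to compound 3 (0.05 log units; within the scatter). Compound 3 is therefore estimated at 350 nM, with a range from 150 nM to 800 nM.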

Compound 3, half-maximal inhibitory concentration: 2150 nM
For compound 3 the middle estimate is 6.1-fold (0.79 log units) below the measured one, and the stated range ends below it.
By their numbers in this assay, from the lowest: compounds 2 and 1 (each within the scatter of the next); then compound 3.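

In this assay this nitrogen proves not to be indifferent to the aryl group it carries: swapping 2-chlorophenyl for 4-methylphenyl gives a 6.9-fold higher number from compound 2 to compound 3 (0.84 log units; beyond the scatter), whereas the earlier aryl swap stayed within the scatter. The pair that differs only in the group on the aromatic carbon, methyl in place of fluoro, gives a 6.1-fold higher number from compound 1 to compound 3 (0.79 log units; beyond the scatter), so that single replacement is enough to set compound 3 apart from compound 1. Nothing available explains why these steps arise.

The compounds shown leave open whether the methyl group itself sets the higher number, or whether the fluoro and chloro groups each hold it down. On these data alone, whether plain phenyl, 4-methoxyphenyl or 2-methylphenyl on the same nitrogen would fall with compound 2 or with compound 3 also remains open.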